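Working notes: the step from compound 2 to compound 4

A few compounds are considered here, and "the series" means these few. Any claim that something is new, unique, unknown or untested is made for them only; others in the source may bear on it.

compound 1 `CCN(CC)C(=O)c1ccccc1OCC1=NCCN1` — < 5020 nM
compound 2 `c1ccc(-c2ccncc2)c(OCC2=NCCN2)c1` — < 100000 nM
compound 3 `Cc1cccc(-c2ccccc2OCC2=NCCN2)n1` — < 100000 nM

All three values come from a functional assay for activation of Alpha-1D adrenergic receptor (Homo sapiens), read by calcium flux (a higher number here means that more compound is needed for the effect, a lower number that less compound is needed), and none is a number. For compound 2 the value < 100000 nM is a limit of the assay (the limit of < 100000 nM in this assay, at which 2 of the 3 values shown sit). For compound 3 the value < 100000 nM is also a limit. For compound 1 the value < 5020 nM is a limit as well (the limit of < 5020 nM in this assay, at which 1 of the 3 values shown sits). Where compound 2 stands can therefore not be fixed beyond its limit. Compound 4 `c1ccc(-c2cnccn2)c(OCC2=NCCN2)c1` differs from compound 2 by pyrazin-2-yl in place of pyridin-4-yl on an aromatic carbon. Among the compounds with values here, no step between measured compounds is known, so in this assay no step beyond the scatter is expected from compound 2 to compound 4. Compound 4 is expected at 30000 nM, between 3000 nM and 100000 nM, the step that the limit leaves unreadable from compound 2 to compound 4 being expected to stay small.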

Compound 4, half-maximal effective concentration: < 100000 nM
Compound 4: a limit, no number; the forecaster's own chance of this, stated with the estimate: 60%; the middle value does not contradict the limit.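

In this assay, within the data shown here, compound 2 and compound 4 are both limits rather than numbers, so no step between them can be read. The compounds shown leave open whether pyrazin-2-yl and pyridin-4-yl differ at all in this assay.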